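Shrinking the ring on the core nitrogen

This account rests on a few compounds, and the source may have more. Where it says the series, first, only, none or still open, it means among the compounds named here.

Compound 2 `CC(=O)C1CCC(Cn2c(-c3ccc(OCc4c(-c5c(Cl)cccc5Cl)noc4C(C)C)cc3)nc3ccc(C(=O)O)cc32)CC1` gives the highest of the two numbers measured in an assay on Huh-7 cells for agonist activity at Bile acid receptor (Homo sapiens), read by a luciferase reporter (a higher number here means that more compound is needed for the effect, a lower number that less compound is needed), namely 1170 nM. Going by the values given here, its nearest neighbour is compound 1 `CC(C)c1onc(-c2c(Cl)cccc2Cl)c1COc1ccc(-c2nc3ccc(C(=O)O)cc3n2C2CCCCC2)cc1`, which in this assay gives 4.21 nM; the only change between them, a 280-fold higher number from compound 1 to compound 2 (2.44 log units; beyond the scatter), is large. Compound 3 `CC(C)c1onc(-c2c(Cl)cccc2Cl)c1COc1ccc(-c2nc3ccc(C(=O)O)cc3n2C2CCC2)cc1` differs from compound 2 by cyclobutyl in place of (4-acetylcyclohexyl)methyl on an aromatic nitrogen. Because the related step of a 280-fold higher number from compound 1 to compound 2 (2.44 log units; beyond the scatter) shows that placing the large group on this nitrogen raised the number steeply, returning to a small ring is expected to bring it far down again, close to compound 1. Compound 3 is therefore estimated at 15 nM, between 3 nM and 80 nM, a drop of a 78-fold lower number from compound 2 to compound 3 (1.89 log units; beyond the scatter).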

Compound 3, half-maximal effective concentration: 14.4 nM
Compound 3: the middle estimate sits 1.0-fold (0.02 log units) above what was measured; measured number inside the range.
By their numbers in this assay, from the lowest: compound 1; then compound 3; then compound 2.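

Going back to a small ring on this nitrogen recovers nearly all of what the large group cost in this assay (an 81-fold lower number from compound 2 to compound 3 (1.91 log units; beyond the scatter)). Ring size still matters here, though: cyclobutyl does not quite match cyclohexyl (a 3.4-fold higher number from compound 1 to compound 3 (0.53 log units; beyond the scatter)). No measurement shown here explains either shift.

On these data alone, compound 2 differs from compound 1 in both its acetyl group and its methyl link, so the share of each in the loss remains unknown. Also open, as far as these compounds go, is how a cyclopentyl ring, or a cyclohexyl ring bearing an amine, would fare at this position.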